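Pyridinyl ethynyl isomers at the cytotoxicity limit

A few compounds are considered here, and "the series" means these few. Any claim that something is new, unique, unknown or untested is made for them only; others in the source may bear on it.

Compound 1 `CNC(=O)[C@@H](NC(=O)[C@@](O)(CCCN(Cc1ccc(-c2ccccc2)cc1)NC(=O)[C@@H](NC(=O)OC)C(C)(C)C)Cc1ccccc1)C(C)(C)C` carries a phenyl group where compound 2 `CNC(=O)[C@@H](NC(=O)[C@@](O)(CCCN(Cc1ccc(C#Cc2ccccn2)cc1)NC(=O)[C@@H](NC(=O)OC)C(C)(C)C)Cc1ccccc1)C(C)(C)C` and compound 3 `CNC(=O)[C@@H](NC(=O)[C@@](O)(CCCN(Cc1ccc(C#Cc2cccnc2)cc1)NC(=O)[C@@H](NC(=O)OC)C(C)(C)C)Cc1ccccc1)C(C)(C)C` carry pyridinyl ethynyl groups, and compound 4 `CNC(=O)[C@@H](NC(=O)[C@@](O)(CCCN(Cc1ccc(C#Cc2ccncc2)cc1)NC(=O)[C@@H](NC(=O)OC)C(C)(C)C)Cc1ccccc1)C(C)(C)C` is the remaining isomer on the same core. In an ADME assay on MT4 cells (Homo sapiens) for cytotoxicity, read by XTT assay, with a stated time of 5 days (on this read-out higher numbers stand for lower toxicity in this test and lower numbers for higher toxicity in this test), compound 1 gives > 50000 nM, which is a limit. Compound 2 gives > 50000 nM, also a limit. Compound 3 gives > 50000 nM, again a limit, so it has no numerical rank in the series. Among the measured compounds shown here, the only reading so far is the limit of > 50000 nM in this assay, at which 3 of the 3 values shown sit.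

The change to compound 4 is pyridin-4-yl in place of pyridin-3-yl on a triple-bonded carbon. For the measured compounds named here, the closest precedent is a step that the two limits leave unreadable from compound 2 to compound 3. The replacements of phenyl give a step that the two limits leave unreadable from compound 1 to compound 2 and a step that the two limits leave unreadable from compound 1 to compound 3. None of these sizes can be carried over, so no step beyond the scatter is expected in this assay, in either direction. The estimated step is a number no higher from compound 3 to compound 4 (the limit leaves the size open). Compound 4 is expected at 50000 nM, with an estimated range of 25000 nM to 100000 nM, and will most likely be reported as a limit again.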

Compound 4, half-maximal cytotoxic concentration: > 50000 nM
Compound 4 was reported as a limit; the forecaster's own chance of this, stated with the estimate: 90%; the middle value sits exactly at the limit.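

In this assay compound 4 gives > 50000 nM, which is a limit. Among the compounds shown here, no step among compound 1, compound 2, compound 3 and compound 4 can be read, and all four share one limit: the limit of > 50000 nM in this assay, at which 4 of the 4 values shown sit. The compounds shown leave open how the phenyl compound and the three pyridinyl ethynyl isomers rank in cytotoxicity.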